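A few compounds are considered here, and "the series" means these few. Any claim that something is new, unique, unknown or untested is made for them only; others in the source may bear on it.

Working notes on the series.

Compound 1 `Oc1ccc(-c2nc3cc(Cl)c(Cl)cc3[nH]2)cc1` and compound 2 `O=C(CN1CCCC1)Nc1ccc(-c2nc3cc(Cl)c(Cl)cc3[nH]2)cc1` share a core and have both been run in an ADME assay on BHK cells (Mesocricetus auratus) for cytotoxicity, read by MTT assay, with a stated time of 96 h; a lower number here means that less compound is tolerated, a higher number that more compound is tolerated. In this assay compound 1 gives 29000 nM. In this assay, among the measured compounds shown here, compound 2 gives 64000 nM, the highest of the two numbers so far; its nearest neighbour is compound 1, whose number is lower by more than the usual scatter.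

Compound 3 `CC(=O)Nc1ccc(-c2nc3cc(Cl)c(Cl)cc3[nH]2)cc1` has not yet been measured in this assay. It differs from compound 2 in one place: hydrogen in place of pyrrolidin-1-yl on a saturated chain carbon bound to a carbonyl carbon. For the measured compounds named here, no step between two measured compounds carries this exact change, so nothing measured says how it should read. The expectation is a step from compound 2 to compound 3 of a 1.4-fold lower number from compound 2 to compound 3 (0.15 log units; within the scatter), pulling the number downward, but only to a degree that may not clear the scatter. Compound 3 is therefore estimated at 45000 nM, with a likely range from 20000 nM to 100000 nM.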

Compound 3, half-maximal cytotoxic concentration: > 100000 nM
Compound 3: no number, only a limit; the forecaster's own chance of this, stated with the estimate: 10%; at least 2.2-fold (0.34 log units) between middle value and limit.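

Compound 3 gives no number in this assay, only a limit: the limit of > 100000 nM in this assay, at which 1 of the 3 values shown sits. On a saturated chain carbon bound to a carbonyl carbon, hydrogen in place of pyrrolidin-1-yl does not bring the lower number that the earlier compounds left possible: the step is an at least 1.5-fold higher number from compound 2 to compound 3 (0.19 log units; that floor lies within the scatter), so this change is not shown to exceed the scatter, yet the pyrrolidin-1-yl group is not needed to reach the top of the measured range. Acetamido in place of hydroxy on an aromatic carbon gives an at least 3.4-fold higher number from compound 1 to compound 3 (0.53 log units; beyond the scatter), a change that clears the scatter even at its floor.

As far as these compounds go, both steps are floors, so their full size stays open. Also open, from the compounds shown here alone, is whether a primary amine, a carboxylic acid or a longer chain at this saturated chain carbon would read like hydrogen or like pyrrolidin-1-yl.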